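Dichloro extension of the diaryl ether series

A few compounds are considered here, and "the series" means these few. Any claim that something is new, unique, unknown or untested is made for them only; others in the source may bear on it.

Measured in an assay on microsomes from brain (strain Sprague-Dawley) for inhibition of Fatty-acid amide hydrolase 1 (Rattus norvegicus), read by HPLC, with stated times of 10 min and 45 min; a lower number here means a stronger inhibitor, a higher number a weaker inhibitor:
compound 1, `CN(C)C(=O)n1nnc(-c2ccc(Oc3ccc(Cl)cc3)cc2)n1`, gives 16 nM;
compound 2, `Cc1ccc(Oc2ccc(-c3nnn(C(=O)N(C)C)n3)cc2)cc1`, gives 24 nM;
compound 3, `CN(C)C(=O)n1nnc(-c2ccc(Oc3cccc(Cl)c3)cc2)n1`, gives 9 nM.

Compound 3 gives the smallest number of the three. One of its steps is a 1.8-fold lower number from compound 1 to compound 3 (0.25 log units; within the scatter), so those two are not separated by the data; the other is a 2.7-fold lower number from compound 2 to compound 3 (0.43 log units; beyond the scatter).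

Compound 4, `CN(C)C(=O)n1nnc(-c2ccc(Oc3ccc(Cl)c(Cl)c3)cc2)n1`, is not yet measured. Against compound 3 the change is chloro in place of hydrogen on an aromatic carbon. The chloro enters on an aromatic carbon of the six-membered ring of carbon only, ortho to a chloro group and para to a large group; read one bond further out, 3-chlorophenyl becomes 3,4-dichlorophenyl.

For the measured compounds named here, two measured steps bear on this. a 1.8-fold lower number from compound 1 to compound 3 (0.25 log units; within the scatter) shows that placing the single chloro at either position gives numbers within the scatter of each other. a 1.5-fold higher number from compound 1 to compound 2 (0.18 log units; within the scatter) shows that the para substituent itself, chloro or methyl, barely moves this assay. Compound 4 carries both chloro positions at once; nothing measured points to a step beyond the scatter in either direction.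

Compound 4 is therefore expected near 8 nM, with a range of 3 nM to 20 nM. The expected step is a 1.1-fold lower number from compound 3 to compound 4 (0.05 log units; within the scatter).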

Compound 4, half-maximal inhibitory concentration: 11 nM
Compound 4: the middle estimate sits 1.4-fold (0.14 log units) below what was measured; the range from low to high includes it.
By their numbers in this assay, from the lowest: compounds 3, 4, 1 and 2 (each within the scatter of the next, the first and the last beyond it).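

In this assay, a second chloro on the ring carbon ortho to a chloro group gives no separation from the 3-chlorophenyl compound (a 1.2-fold higher number from compound 3 to compound 4 (0.09 log units; within the scatter)), and a chloro in place of hydrogen on the 4-chlorophenyl compound gives none either (a 1.5-fold lower number from compound 1 to compound 4 (0.16 log units; within the scatter)). The earlier compounds shown here showed only single substituents, so this position is now seen to carry a chloro alongside another chloro with the number staying within the scatter of both parents, while 3,4-dichlorophenyl remains separated from 4-methylphenyl (a 2.2-fold lower number from compound 2 to compound 4 (0.34 log units; beyond the scatter)). No evidence on the cause of these steps is available.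

Chloro is the only group shown entering this position, so it remains open whether an amine, a carboxylic acid or a longer chain in place of the hydrogen would leave the number within the scatter or move it beyond. Also open, going by these compounds, is whether a methyl group in place of either chloro of the 3,4-dichlorophenyl group would keep the number where compound 4 stands.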